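The compounds below may be only part of what the source reports. "The series", "measured", "known", "first", "only" and "open" are said of these compounds alone.

Series notes. The shared core is carried by compound 1 `CCCCCCCCCCc1cn(C[C@H](O)[C@H]2OC(=O)C(OCc3ccccc3)=C2OCc2ccccc2)nn1`, compound 2 `CC(C)(C)c1cn(C[C@H](O)[C@H]2OC(=O)C(OCc3ccccc3)=C2OCc2ccccc2)nn1` and compound 3 `Cc1ccc(-c2cn(C[C@H](O)[C@H]3OC(=O)C(OCc4ccccc4)=C3OCc3ccccc3)nn2)cc1`, which differ only in the group on the aromatic carbon of the five-membered ring. In a functional assay on HeLa cells (Homo sapiens) for antiproliferative activity, read by MTT assay, with a stated time of 72 h (on this read-out lower numbers stand for stronger inhibition and higher numbers for weaker inhibition), compound 1 gives 22900 nM, compound 2 gives 18300 nM and compound 3 gives 25500 nM. Compound 3 returns the highest of the three numbers, but its separation from the others is nominal: a 1.1-fold higher number from compound 1 to compound 3 (0.05 log units; within the scatter) and a 1.4-fold higher number from compound 2 to compound 3 (0.14 log units; within the scatter), as is a 1.3-fold lower number from compound 1 to compound 2 (0.10 log units; within the scatter). Swapping a decyl chain, a tert-butyl or a 4-methylphenyl at that position has therefore left this assay unmoved.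

Compound 4 `COc1ccc(-c2cn(C[C@H](O)[C@H]3OC(=O)C(OCc4ccccc4)=C3OCc3ccccc3)nn2)cc1` takes the change (methoxy in place of methyl on an aromatic carbon). For the measured compounds named here, no measured step involves a methoxy, so nothing bears on it directly; the only guide is that every change at this position so far stayed within the scatter. On that basis the expected step of a 1.1-fold lower number from compound 3 to compound 4 (0.03 log units; within the scatter) is none beyond the scatter. Compound 4 is estimated at 24000 nM, with a range from 11000 nM to 52000 nM.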

Compound 4, half-maximal inhibitory concentration: 16400 nM
Compound 4: middle estimate off by 1.5-fold (0.17 log units), on the high side, and the stated range covers the measured number.
By their numbers in this assay, from the lowest: compounds 4, 2, 1 and 3 (each within the scatter of the next).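

In this assay the series now has its first change that adds a hydrogen-bond acceptor, and going from 4-methylphenyl to 4-methoxyphenyl stays within the scatter (a 1.6-fold lower number from compound 3 to compound 4 (0.19 log units; within the scatter)). The 4-methoxyphenyl group also remains level with the two non-aromatic groups, tert-butyl (a 1.1-fold lower number from compound 2 to compound 4 (0.05 log units; within the scatter)) and decyl (a 1.4-fold lower number from compound 1 to compound 4 (0.14 log units; within the scatter)), so all four compounds now sit together whether the group at this position is an alkyl chain, a branched alkyl or a substituted phenyl. No measurement at hand speaks to why these numbers sit together.

From the compounds shown here alone, whether an amine or a carboxylic acid in place of the methoxy would separate from this cluster remains open. Also open, going by these compounds, is whether a change elsewhere on the shared core would move the number at all.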